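A few compounds are considered here, and "the series" means these few. Any claim that something is new, unique, unknown or untested is made for them only; others in the source may bear on it.

Working notes on the series. Compound 1 `COC[C@H]1C[C@@](CC(C)C)(C(=O)O)N(C(=O)c2ccc(C(C)(C)C)c(OC)c2)[C@H]1[C@H]1COC(C)(C)O1` is the starting point. In an ADME assay on Huh-5-2 cells (Homo sapiens) for cytotoxicity, with a stated time of 3 days (a higher number here means that more compound is tolerated, a lower number that less compound is tolerated), compound 1 gives > 120000 nM, which is a limit of the assay. Going by the values given here, compound 2 `COC[C@H]1C[C@@](CC(C)C)(C(=O)O)N(C(=O)c2ccc(C(C)(C)C)c(OC)c2)[C@H]1C(N)=O` carries the one measured change. In this assay compound 2 gives > 120000 nM, again a limit. Among the compounds with values here, the only measured step, a step that the two limits leave unreadable from compound 1 to compound 2, therefore cannot be read, since both values rest at the limit of > 120000 nM in this assay, at which 2 of the 2 values shown sit. Compound 2 thus stands at the limit of this assay, without a number that would place it relative to compound 1.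

Compound 3 `COC[C@H]1C[C@@](CC(C)C)(C(=O)O)N(C(=O)c2ccc(C(C)(C)C)c(OC)c2)[C@H]1COC` is not yet measured. The change is methoxymethyl in place of carbamoyl on a saturated ring carbon. Within the data shown here, no measured step bears on this change, and the one step that is known is unreadable. Compound 3 is therefore expected to remain at the limit as well, with an expected step that the limit leaves unreadable from compound 2 to compound 3. The estimate for compound 3 in this assay is 150000 nM, with a range from 70000 nM to 350000 nM.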

Compound 3, half-maximal cytotoxic concentration: > 120000 nM
Compound 3: no number, only a limit; the forecaster's own chance of this, stated with the estimate: 80%; the middle value is on the limit's open side.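

Going by these compounds alone, no step among compound 1, compound 2 and compound 3 can be read in this assay, since all three values rest at a limit: the limit of > 120000 nM in this assay, at which 3 of the 3 values shown sit. The compounds shown leave open whether any group on this saturated ring carbon would give a measurable cytotoxic concentration.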